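The source may hold more compounds than are shown below. What is called first, only, known or untested is meant among the compounds shown, and "the series" means these compounds.

Measured compounds:
compound 1 `N#Cc1ccc(-c2cs/c(=N/NC(=O)CSc3ncccn3)n2-c2ccccc2)cc1` — in a functional assay on C6 cells (Rattus norvegicus) for cytotoxicity, read by MTT assay, with a stated time of 24 h (on this read-out lower numbers stand for stronger inhibition and higher numbers for weaker inhibition), compound 1 gives "not determined" (no result reported)
compound 2 `Cc1ccc(-c2cs/c(=N/NC(=O)CSc3ncccn3)n2-c2ccccc2)cc1` — 85 ug/mL
compound 3 `COc1ccc(-c2cs/c(=N/NC(=O)CSc3ncccn3)n2-c2ccccc2)cc1` — 102 ug/mL

Compound 1 stands without a single number in this assay, so its position can only be read from its two close relatives. Compound 2 and compound 3 share the same core and differ only on the aromatic carbon; the step of a 1.2-fold higher number from compound 2 to compound 3 (0.08 log units; within the scatter) is within the scatter, so the two give what is in effect one reading for this family.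

Compound 4 `N#Cc1ccc(-c2cs/c(=N/NC(=O)CSc3nnnn3-c3ccccc3)n2-c2ccccc2)cc1` arises from compound 1 by 1-phenyl-1H-tetrazol-5-yl in place of pyrimidin-2-yl on a sulfur. Among the measured compounds shown here, the only measured step changes a different part of the molecule, so no step bears directly on this change, and no direction can be taken from it. The expectation therefore rests on the narrow band set by compound 2 and compound 3, with a wide range to cover the unknown effect of the new group.

Compound 4 is estimated at 95 ug/mL, with a range of 40 ug/mL to 220 ug/mL.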

Compound 4, half-maximal inhibitory concentration: > 200 ug/mL
Compound 4 gave a limit, no number (the forecaster's own chance of this, stated with the estimate: 20%); middle value at least 2.1-fold (0.32 log units) away from the limit.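

In this assay compound 4 gives > 200 ug/mL, which is a limit and not a number. Among the compounds shown here, compound 1 has no single number here, so no step between compound 1 and compound 4 can be read. As far as these compounds go, how far 1-phenyl-1H-tetrazol-5-yl in place of pyrimidin-2-yl shifts the reading stays open.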